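Moving the fluorine on the phenyl group

The compounds below may be only part of what the source reports. "The series", "measured", "known", "first", "only" and "open" are said of these compounds alone.

In an ADME assay on HepG2 cells (Homo sapiens) for inhibition, read by resazurin assay, with a stated time of 48 h (a lower number here means that less compound is needed, a higher number that more compound is needed for the effect), compound 1 (`O=C(Nc1ccc2sc(-c3ccccc3)nc2c1)N1CCCCC1`) gives > 50 uM, which is a limit of the assay. Compound 2 (`O=C(Nc1ccc2sc(-c3ccc(F)cc3)nc2c1)N1CCCCC1`) gives > 50 uM, also a limit and not a number. Compound 2 therefore stands at the limit of > 50 uM in this assay, at which 2 of the 2 values shown sit. Compound 3 (`O=C(Nc1ccc2sc(-c3ccccc3F)nc2c1)N1CCCCC1`) differs from compound 2 as follows: 2-fluorophenyl in place of 4-fluorophenyl on an aromatic carbon. Among the compounds with values here, the only measured step that bears on this change is a step that the two limits leave unreadable from compound 1 to compound 2, and it has no readable size. No shift beyond the scatter is expected in this assay, and another limit is the likeliest report. The expected step is a number no higher from compound 2 to compound 3 (the limit leaves the size open). The estimate for compound 3 is 50 uM, with an expected range of 25 uM to 100 uM.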

Compound 3, concentration for 90% of the maximal effect: > 50 uM
Compound 3 ended at the assay's limit; the forecaster's own chance of this, stated with the estimate: 80%; the middle value lies on the limit itself.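

Compound 1, compound 2 and compound 3 all give limits and not numbers in this assay, so no step among them can be read: the limit of > 50 uM in this assay, at which 3 of the 3 values shown sit.

The compounds shown leave open whether 2-fluorophenyl and 4-fluorophenyl differ at all in this assay.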